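The compounds below may be only part of what the source reports. "The series", "measured", "known", "first", "only" and "open" are said of these compounds alone.

Compound 1, `CN(C)CCn1cnnc1-c1cc(Oc2ccc(NC(=O)N/N=C/c3ccc(O)c(O)c3)cc2F)ccn1`, gives 3240 nM in a functional assay on MKN-45 cells (Homo sapiens) for cytotoxicity, read by MTT assay, with a stated time of 72 h; on this read-out higher numbers stand for weaker inhibition and lower numbers for stronger inhibition.
Compound 2, `CN(C)CCn1cnnc1-c1cc(Oc2ccc(NC(=O)N/N=C/c3ccc(O)c(F)c3)cc2F)ccn1`, gives 1970 nM in this assay.

For the measured compounds named here, on these two numbers compound 2 stands at the lower end, with compound 1 as its only neighbour, but the step of a 1.6-fold lower number from compound 1 to compound 2 (0.22 log units; within the scatter) lies within the scatter, so the two compounds are not separated by this assay.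

Compound 3, `CN(C)CCn1cnnc1-c1cc(Oc2ccc(NC(=O)N/N=C/c3ccc(F)cc3Cl)cc2F)ccn1`, has not yet been measured in this assay. It differs from compound 2 by 2-chloro-4-fluorophenyl in place of 3-fluoro-4-hydroxyphenyl on a carbon with a double bond to nitrogen. Going by the values given here, only one measured step bears on this change: a 1.6-fold lower number from compound 1 to compound 2 (0.22 log units; within the scatter), in which fluoro took the place of hydroxy on the same ring and which stayed within the scatter. The present change goes further, taking away the remaining hydroxy and the fluoro together and bringing in a ring with chloro and fluoro and no hydrogen-bond donor or acceptor. Among the compounds with values here, no measured step covers the loss of the second hydroxy or the entry of chloro, so the direction is open. Compound 3 is therefore expected to show a step of a 1.1-fold higher number from compound 2 to compound 3 (0.05 log units; within the scatter) that stays within the scatter. The estimate for compound 3 is 2200 nM, with a range from 700 nM to 7000 nM.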

Compound 3, half-maximal inhibitory concentration: 870 nM
Compound 3: the middle estimate sits 2.5-fold (0.40 log units) above what was measured, within the range that was stated.
By their numbers in this assay, from the lowest: compound 3; then compounds 2 and 1 (each within the scatter of the next).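

In this assay, the ring on a carbon with a double bond to nitrogen now gives a step beyond the scatter: 2-chloro-4-fluorophenyl in place of 3-fluoro-4-hydroxyphenyl gives a modest change (a 2.3-fold lower number from compound 2 to compound 3 (0.35 log units; beyond the scatter)), and the same ring in place of 3,4-dihydroxyphenyl gives another (a 3.7-fold lower number from compound 1 to compound 3 (0.57 log units; beyond the scatter)). The earlier swap of hydroxy for fluoro did not separate its two compounds, whereas this larger change shows that the number at this position can move, and that a ring with 0 hydrogen-bond donors gives the lowest number of the three. No evidence is available on why the number moved.

The ring of compound 3 loses the hydroxy and gains chloro in one change, so the compounds shown leave open which of these carries the step, and whether the fluoro must also move for it to appear. They also leave open how this position would read with a methoxy group, an amine or a carboxylic acid on the ring, or with a plain phenyl ring.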